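Swapping Bromo for Trifluoromethoxy on Compound 2

The compounds below may be only part of what the source reports. "The series", "measured", "known", "first", "only" and "open" are said of these compounds alone.

Of the compounds shown here, three built on one shared core have been measured in an ADME assay on Vero cells (Chlorocebus sabaeus) for cytotoxicity, read by resazurin assay, with a stated time of 72 h; on this read-out higher numbers stand for weaker inhibition and lower numbers for stronger inhibition. Compound 1 (`O=C(CCN1CCN(c2ccc(C(F)(F)F)cc2)CC1)c1ccccc1`) gives 15700 nM, compound 2 (`O=C(CCN1CCN(c2ccc(C(F)(F)F)cc2)CC1)c1ccc(Br)cc1`) gives 78800 nM, and compound 3 (`O=C(CCN1CCN(c2ccc(C(F)(F)F)cc2)CC1)c1ccc(Cl)c(F)c1`) gives 74300 nM. The gap between the last two, a 1.1-fold lower number from compound 2 to compound 3 (0.03 log units; within the scatter), lies within the scatter, so they stand level. Two modest steps beyond the scatter separate that pair from the remaining compound: a 5.0-fold higher number from compound 1 to compound 2 (0.70 log units; beyond the scatter) and a 4.7-fold higher number from compound 1 to compound 3 (0.68 log units; beyond the scatter).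

Compound 4 (`O=C(CCN1CCN(c2ccc(C(F)(F)F)cc2)CC1)c1ccc(OC(F)(F)F)cc1`) makes a single change to compound 2: trifluoromethoxy in place of bromo on an aromatic carbon, para to a large group (trifluoromethoxy in place of bromo on an aromatic carbon). Going by the values given here, no measured step makes this exact swap. The nearest guide is a 1.1-fold lower number from compound 2 to compound 3 (0.03 log units; within the scatter), another exchange of substituted rings, and it stayed within the scatter. The step of a 5.0-fold higher number from compound 1 to compound 2 (0.70 log units; beyond the scatter) shows that a larger move is possible on this ring, but it starts from an unsubstituted ring, which the present change does not. The expected step is therefore small, a 1.1-fold lower number from compound 2 to compound 4 (0.05 log units; within the scatter), and no change beyond the scatter is expected. For compound 4 the estimated value in this assay is 70000 nM, with an expected range from 30000 nM to 130000 nM.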

Compound 4, half-maximal inhibitory concentration: 64900 nM
Compound 4: middle estimate off by 1.1-fold (0.03 log units), on the high side, within the range that was stated.
By their numbers in this assay, from the lowest: compound 1; then compounds 4, 3 and 2 (each within the scatter of the next).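

In this assay, putting trifluoromethoxy in place of bromo on this aromatic carbon, para to a large group, gives a 1.2-fold lower number from compound 2 to compound 4 (0.08 log units; within the scatter), so a group of 5 heavy atoms with 1 hydrogen-bond acceptor takes the place of a single bromine atom with no change that can be told from the scatter. Measured against the unsubstituted ring, the same group gives a 4.1-fold higher number from compound 1 to compound 4 (0.62 log units; beyond the scatter), which means that compounds 2, 3 and 4, with three different substituted rings, now all stand level with one another and apart from the unsubstituted compound, a pattern that no compound shown goes against. No evidence is available that bears on what lies behind this result.

All the substituents shown at this position contain a halogen, so it remains open whether a group without one, such as an amine, a carboxylic acid or a longer carbon chain, would stand level with them or move the number further. As far as these compounds go, it is also open whether trifluoromethoxy would give a similar result on a different aromatic carbon or alongside a change elsewhere in the shared core.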